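The source may hold more compounds than are shown below. What is called first, only, known or untested is meant among the compounds shown, and "the series" means these compounds.

Compound 1 `CCN(Cc1cccs1)C(=O)COc1ccc(C)cc1` gives 8 nM in an assay on HEK293 cells for agonist activity at transient receptor potential cation channel subfamily M member 8 (Homo sapiens), read by fluorescence and calcium flux, with a stated time of 15 min; a lower number here means that less compound is needed, a higher number that more compound is needed for the effect.
Compound 2 `Cc1ccc(OCC(=O)N(Cc2cccs2)c2ccon2)cc1` gives 2 nM in this assay.

Within the data shown here, compound 2 stands at the lowest of the two numbers measured so far; the only other measured compound is compound 1, and the step of a 4.0-fold lower number from compound 1 to compound 2 (0.60 log units; beyond the scatter) lies beyond the scatter. Compound 3 `Cc1ccc(OCC(=O)N(Cc2cccs2)c2cnccn2)cc1` differs from compound 2 in one place: pyrazin-2-yl in place of 1,2-oxazol-3-yl on an amide-type nitrogen. Among the measured compounds shown here, no measured step changes one aromatic ring on the amide-type nitrogen for another, so no step bears directly on it. For the measured compounds named here, the one step that is known, a 4.0-fold lower number from compound 1 to compound 2 (0.60 log units; beyond the scatter), only shows that an aromatic ring in place of ethyl on that nitrogen lowered the number. Since compound 3 keeps an aromatic ring with two hydrogen-bond acceptors at that nitrogen, the change from compound 2 is expected to give a 1.5-fold higher number from compound 2 to compound 3 (0.18 log units; within the scatter), that is, nothing beyond the scatter. Compound 3 is therefore expected to give about 3 nM, in a range from 1 nM to 10 nM.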

Compound 3, half-maximal effective concentration: 1240 nM
Compound 3: middle estimate off by 410-fold (2.62 log units), on the low side; measured number above the stated range.
By their numbers in this assay, from the lowest: compound 2; then compound 1; then compound 3.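

The aromatic ring on the amide-type nitrogen cannot be swapped freely in this assay: pyrazin-2-yl in place of 1,2-oxazol-3-yl gives a 620-fold higher number from compound 2 to compound 3 (2.79 log units; beyond the scatter), although both groups have the same counts of hetero atoms, hydrogen-bond donors and acceptors and neither carries a net charge. An aromatic ring at this position therefore does not lower the number as such, since a 4.0-fold lower number from compound 1 to compound 2 (0.60 log units; beyond the scatter) now stands against a 160-fold higher number from compound 1 to compound 3 (2.19 log units; beyond the scatter), with pyrazin-2-yl in place of ethyl. Nothing available explains why these two rings differ so sharply.

Ring size and the identity of the hetero atoms change together in this single swap, so their separate contributions remain open. A plain phenyl or a pyridin-2-yl group on that nitrogen could begin to separate them.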